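The source may hold more compounds than are shown below. What is called first, only, known or untested is meant among the compounds shown, and "the series" means these compounds.

For the measured compounds named here, compound 1 `CCC[C@@H]1C(=O)N(C)c2cnc(Nc3ccc(C(=O)NC4CCN(C)CC4)cc3OC)nc2N1C1CCCC1` and compound 2 `C[C@@H]1C(=O)N(C)c2cnc(Nc3ccc(C(=O)NC4CCN(C)CC4)cc3OC3CCCC3)nc2N1C1CCCC1` share the same core and differ from one another in two places at once, so no single step links them. In an assay on isolated protein for inhibition of serine/threonine-protein kinase PLK1 (Homo sapiens), read by Z'-LYTE (a higher number here means a weaker inhibitor, a lower number a stronger inhibitor), compound 1 gives 9.9 nM, and in this assay compound 2 gives 40 nM. Of the two numbers compound 2 stands at the higher one, and the gap between them lies beyond the usual scatter of repeated measurements.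

Compound 3 `CCC[C@@H]1C(=O)N(C)c2cnc(Nc3ccc(C(=O)NC4CCN(C)CC4)cc3OC3CCCC3)nc2N1C1CCCC1` is compound 2 with one change: ethyl in place of hydrogen on a saturated chain carbon bound to a saturated ring carbon. Read one bond further out, the change is methyl to propyl on that saturated ring carbon, which gives compound 3 the same chain as compound 1 while it keeps the cyclopentyloxy group of compound 2. Going by the values given here, no measured pair isolates this change, so its size is uncertain, but a modest gain in potency is expected rather than a loss, because compound 1 gives 9.9 nM. The estimated step of a 2.0-fold lower number from compound 2 to compound 3 (0.30 log units; within the scatter) is therefore a small to moderate move toward a lower number. Compound 3 is expected to give about 20 nM, with a range from 8 nM to 50 nM.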

Compound 3, half-maximal inhibitory concentration: 47 nM
Beside the measured number, compound 3's estimate is 2.4-fold (0.37 log units) below it, and the stated range covers the measured number.
By their numbers in this assay, from the lowest: compound 1; then compounds 2 and 3 (each within the scatter of the next).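

In this assay, ethyl in place of hydrogen on a saturated chain carbon bound to a saturated ring carbon gives a 1.2-fold higher number from compound 2 to compound 3 (0.07 log units; within the scatter), so with the cyclopentyloxy group in place, methyl and propyl at this position cannot be told apart. With the propyl chain held, cyclopentyl in place of methyl on an oxygen on an aromatic ring gives a 4.7-fold higher number from compound 1 to compound 3 (0.68 log units; beyond the scatter), and of the two single changes now readable, only this one lies beyond the scatter. Nothing shown gives a reason for either step.

The compounds shown leave open whether the chain on the saturated ring carbon would still make no readable difference with methyl rather than cyclopentyl on the oxygen, and how a longer chain such as butyl would read at that position. They also leave open whether a group of another size on the oxygen, such as ethyl or isopropyl, would stay with the number of compound 1 or with that of compound 3.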